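Swapping the difluorocyclohexyl amide for a fluorophenyl amide

The compounds below may be only part of what the source reports. "The series", "measured", "known", "first", "only" and "open" are said of these compounds alone.

Compound 1 `O=C(C1CCC(F)(F)CC1)N1CC(c2nc(-c3cccc(F)c3)no2)C1` was tested in an assay on HEK293 cells for negative allosteric modulation of metabotropic glutamate receptor 5 (Homo sapiens), read by FLIPR; on this read-out lower numbers stand for stronger inhibition and higher numbers for weaker inhibition. In this assay compound 1 gives only a limit of > 10000 nM. Compound 2 `O=C(C1CCC(F)(F)CC1)N1CC(c2nc(-c3cccc(Cl)c3)no2)C1` likewise gives only a limit of > 10000 nM. The step that the two limits leave unreadable from compound 1 to compound 2 cannot be read, since (the limit of > 10000 nM in this assay, at which 2 of the 2 values shown sit). Compound 3 `O=C(c1ccc(F)cc1)N1CC(c2nc(-c3cccc(F)c3)no2)C1` differs from compound 1 by 4-fluorophenyl in place of 4,4-difluorocyclohexyl on a carbonyl carbon, on the carbonyl carbon whose other neighbour is an amide-type nitrogen in a ring. No measured step touches this carbonyl position, so no direction can be drawn from the shown values, and compound 3 is expected to stay near the limit, with a step of a number no higher from compound 1 to compound 3 (the limit leaves the size open). Compound 3 is estimated at 10000 nM, within 2000 nM to 30000 nM.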

Compound 3, half-maximal inhibitory concentration: > 10000 nM
Compound 3: no number, only a limit; the forecaster's own chance of this, stated with the estimate: 70%; the middle value sits exactly at the limit.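

Compound 3 gives only a limit of > 10000 nM in this assay, so its step from compound 1 cannot be read: the limit of > 10000 nM in this assay, at which 3 of the 3 values shown sit. The compounds shown leave open whether 4-fluorophenyl in place of 4,4-difluorocyclohexyl changes inhibition at all.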